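The compounds below may be only part of what the source reports. "The series", "measured", "known", "first", "only" and "open" are said of these compounds alone.

- compound 1 `CC1(C)CC(NC(=O)Nc2ccccc2Cl)c2cc(F)ccc2O1`: 27000 nM
- compound 2 `CC1(C)CC(NC(=O)Nc2ccccc2Cl)c2cc(Cl)ccc2O1`: 20000 nM

In a functional assay on T98G cells (Homo sapiens) for inhibition, read by MTT assay, with a stated time of 72 h (a lower number here means a stronger inhibitor, a higher number a weaker inhibitor), compound 1 gives 27000 nM. Within the data shown here, only one other number is available for comparison, from compound 2 at 20000 nM, and the two cannot be told apart. Among the measured compounds shown here, the only measured step is a 1.4-fold lower number from compound 1 to compound 2 (0.13 log units; within the scatter), with chloro in place of fluoro on an aromatic carbon.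

Compound 3 `CC1(C)CC(NC(=O)Nc2ccc(Cl)cc2)c2cc(F)ccc2O1` keeps the core of compound 1 and changes a different part of the molecule: 4-chlorophenyl in place of 2-chlorophenyl on an amide-type nitrogen. In words, it carries 4-chlorophenyl in place of 2-chlorophenyl on an amide-type nitrogen. For the measured compounds named here, no measured pair tests this kind of change, so the single step above offers only a weak guide. It shows a change elsewhere on the molecule, a 1.4-fold lower number from compound 1 to compound 2 (0.13 log units; within the scatter), that stays small. With nothing to favour either direction, no shift beyond the scatter is expected in this assay, although the uncertainty is wide.

For compound 3 the estimated value is 22000 nM, with an expected range of 7000 nM to 70000 nM. This estimate means an expected 1.2-fold lower number from compound 1 to compound 3 (0.09 log units; within the scatter).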

Compound 3, half-maximal inhibitory concentration: 30000 nM
For compound 3 the middle estimate is 1.4-fold (0.13 log units) below the measured one, within the range that was stated.
By their numbers in this assay, from the lowest: compounds 2, 1 and 3 (each within the scatter of the next).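

Replacing 2-chlorophenyl with 4-chlorophenyl on the amide-type nitrogen gives a 1.1-fold higher number from compound 1 to compound 3 (0.05 log units; within the scatter) in this assay, so for these two placements of the chlorine on the phenyl ring, the compounds cannot be told apart. Among these compounds, the earlier step, a 1.4-fold lower number from compound 1 to compound 2 (0.13 log units; within the scatter), concerned only the halogen on the shared core, whereas this pair is the first to probe the group on the amide-type nitrogen, and it too stays within the scatter. No available information on the compounds offers an explanation for this result.

From the compounds shown here alone, all three compounds carry a chlorophenyl group on that nitrogen, so it remains open whether a different group there, such as an unsubstituted phenyl, a methoxyphenyl or a butyl chain, would move the number beyond the scatter. Going by these compounds, it is also open whether the 4-chlorophenyl group would give a similar number when paired with the chloro group of compound 2, and whether 3-chlorophenyl would fit with the two placements tested here.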